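Swapping the dichlorophenyl of compound 1 for a methylphenyl

The source may report more compounds than this note shows. Statements on the series, on what has been measured and on what is new or still open speak of the compounds shown alone.

For the measured compounds named here, compound 1 `O=C(c1cc(Cl)cc(Cl)c1)c1cc(Cl)ccc1OCCn1ccc(=O)[nH]c1=O` is one of three compounds measured in an ADME assay on MT4 cells (Homo sapiens) for cytotoxicity, read by MTT assay, with a stated time of 4 days; a lower number here means that less compound is tolerated, a higher number that more compound is tolerated. In this assay compound 1 reaches only the limit of the assay, > 284000 nM, so it stands at a limit rather than at a number. Compound 2 `Cc1cc(C)cc(C(=O)c2cc(Cl)ccc2OCCn2c(C)cc(=O)[nH]c2=O)c1` also stops at a limit in this assay, > 303000 nM. Compound 3 `O=C(c1cc(Cl)cc(Cl)c1)c1cc(Br)ccc1OCCn1ccc(=O)[nH]c1=O` gives a limit too, > 258000 nM. The step that the two limits leave unreadable from compound 1 to compound 3 is unreadable; both of its endpoints are limits. Going by the values given here, the three limits (the limit of > 258000 nM in this assay, at which 1 of the 3 values shown sits), the limit of > 284000 nM in this assay, at which 1 of the 3 values shown sits, and the limit of > 303000 nM in this assay, at which 1 of the 3 values shown sits, are all that the measurements show, and no step among them has a readable size.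

Compound 4 `Cc1cccc(C(=O)c2cc(Cl)ccc2OCCn2ccc(=O)[nH]c2=O)c1` has not yet been measured in this assay. It differs from compound 1 by 3-methylphenyl in place of 3,5-dichlorophenyl on a carbonyl carbon. Among the compounds with values here, no measured step covers this change, so nothing in the data points to a shift in either direction beyond the scatter. Compound 4 is expected to give 300000 nM, with a range from 150000 nM to 600000 nM. This estimate rests on compound 1, whose value > 284000 nM is a limit. The step that the limit leaves unreadable from compound 1 to compound 4 is therefore expected to be none beyond the scatter.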

Compound 4, half-maximal cytotoxic concentration: > 325000 nM
Compound 4: no number, only a limit (the forecaster's own chance of this, stated with the estimate: 85%); middle value at least 1.0-fold (0.03 log units) away from the limit.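

Compound 1 and compound 4 both stop at a limit rather than a number, so the step between them, 3-methylphenyl in place of 3,5-dichlorophenyl, cannot be read. In this assay the compounds shown leave open the concentration at which any of them would harm the cells.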